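Replacing methyl with 4-methylphenyl on the amino nitrogen

The compounds below may be only part of what the source reports. "The series", "measured", "known", "first", "only" and "open" are said of these compounds alone.

Of the compounds shown here, three sharing one core have been measured in a functional assay on the whole organism (strain BALB/c) for inhibition, with Mus musculus as the target, read by paw edema, with a stated time of 4 h, at a dose of 50 mg/kg by the oral route; on this read-out lower numbers stand for less inhibition and higher numbers for more inhibition at the one dose given (going by the name of the read-out). Compound 1 `CNc1nnc(-c2cc(-c3ccc(F)cc3F)ccc2O)o1` gives 41.4% in this assay, the lowest of the three numbers. Compound 2 `Cn1c(-c2cc(-c3ccc(F)cc3F)ccc2O)n[nH]c1=S` gives 56.9% and compound 3 `CNc1nnc(-c2cc(-c3ccc(F)cc3F)ccc2O)s1` gives 45.4%. The measured steps are a number 15.5 percentage points higher from compound 1 to compound 2 (beyond the scatter), a number 4 percentage points higher from compound 1 to compound 3 (within the scatter) and a number 11.5 percentage points lower from compound 2 to compound 3 (beyond the scatter); each of them exchanges the five-membered ring that carries the core, and none of them touches the substituent on the nitrogen.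

Compound 4 `Cc1ccc(Nc2nnc(-c3cc(-c4ccc(F)cc4F)ccc3O)o2)cc1` has not yet been measured in this assay. It differs from compound 1 by 4-methylphenyl in place of methyl on a nitrogen on an aromatic ring. Among the compounds with values here, no measured step varies this part of the molecule, so there is no direct precedent for the size or direction of its effect. The three measured values all lie in a narrow band, and the exchange of a methyl for a 4-methylphenyl on that nitrogen gives no grounds within these data to expect a move beyond the scatter in either direction.

The expected step is therefore a number 3.6 percentage points higher from compound 1 to compound 4 (within the scatter), with compound 4 estimated at 45% in this assay, ranging from 28% to 62%.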

Compound 4, a percentage reported as inhibition, in the whole organism at one dose (the size of the read-out at that dose, not a potency): 33.8%
Beside the measured number, compound 4's estimate is 11.2 percentage points above it; the range from low to high includes it.
By their numbers in this assay, from the lowest: compounds 4, 1 and 3 (each within the scatter of the next, the first and the last beyond it); then compound 2.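

In this assay, within the data shown here, the exchange of methyl for 4-methylphenyl on the nitrogen gives a number 7.6 percentage points lower from compound 1 to compound 4 (within the scatter), the first reading of a change at this position, since the earlier steps exchanged only the five-membered ring. The step shows that a group of 7 heavy atoms with its own six-membered aromatic ring can replace a single methyl carbon here and the oral read-out at this dose stays within the scatter, so this exchange cannot be told apart from no change, although the step from compound 1 to compound 2 shows that this assay can separate compounds that differ in the ring. Nothing measured on these groups bears on this result, so the data give no explanation for it.

The compounds shown leave open how a longer chain such as butyl, a benzyl group or an unsubstituted phenyl would read on this nitrogen, and whether a carboxylic acid in place of the methyl of the 4-methylphenyl would move the number beyond the scatter. They also leave open whether 4-methylphenyl on the nitrogen of compound 3 would give a similar step.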